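Adding a second chloro to compound 1's core

The source may report more compounds than this note shows. Statements on the series, on what has been measured and on what is new or still open speak of the compounds shown alone.

Among the compounds with values here, compound 1 `ClCc1cccc(Cn2cnc3c(Cl)ncnc32)c1` gives the highest of the two numbers so far: in a functional assay on RPMI-8226 cells (Homo sapiens) for cytotoxicity, read by sulforhodamine B assay, with a stated time of 48 h (a lower number here means a stronger inhibitor of growth, a higher number a weaker inhibitor of growth), compound 1 gives 3800 nM. Its nearest neighbour, compound 2 `ClCc1ccc(Cn2cnc3nc(Cl)nc(Cl)c32)cc1`, gives 1650 nM in this assay, a gap beyond the scatter. Compound 3 `ClCc1cccc(Cn2cnc3c(Cl)nc(Cl)nc32)c1` differs from compound 1 by chloro in place of hydrogen on an aromatic carbon. Within the data shown here, no pair differing in one place has been measured, so the step is expected to be a modest move towards a lower number, a 1.9-fold lower number from compound 1 to compound 3 (0.28 log units; within the scatter). For compound 3 the estimate in this assay is 2000 nM, within a range from 800 nM to 5000 nM.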

Compound 3, concentration for 50% growth inhibition: 3310 nM
Compound 3: the middle estimate sits 1.7-fold (0.22 log units) below what was measured; the range from low to high includes it.
By their numbers in this assay, from the lowest: compounds 2, 3 and 1 (each within the scatter of the next, the first and the last beyond it).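

Within the data shown here, the pair gives the first reading of a single change: chloro in place of hydrogen on an aromatic carbon, between two ring nitrogen atoms, amounts to a 1.1-fold lower number from compound 1 to compound 3 (0.06 log units; within the scatter) in this assay. At this place on the core of compound 1, the chloro therefore cannot be told apart from hydrogen in this read-out. Nothing at hand explains this result. Going by these compounds, whether an amine or a methoxy group at the same place would give a step beyond the scatter remains open. So does whether a hydroxymethyl group in place of the chloromethyl group would alter this picture.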